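The source may hold more compounds than are shown below. What is called first, only, known or untested is meant among the compounds shown, and "the series" means these compounds.

Measured so far in a physicochemical assay for solubility, read by HPLC; a lower number here means a less soluble compound, a higher number a more soluble compound
- compound 1 `O=C(CC1CCCCC1)N1CCN(c2nc(=O)c3cc(C(F)(F)F)cc([N+](=O)[O-])c3s2)CC1` gives 0.12 ug/mL
- compound 2 `CSCC(=O)N1CCN(c2nc(=O)c3cc(C(F)(F)F)cc([N+](=O)[O-])c3s2)CC1` gives 15.2 ug/mL
- compound 3 `CC(=O)N1CCN(c2nc(=O)c3cc(C(F)(F)F)cc([N+](=O)[O-])c3s2)CC1` gives 83.9 ug/mL

Compound 2 stands second highest of the three numbers, with a 5.5-fold higher number from compound 2 to compound 3 (0.74 log units; beyond the scatter) on one side and a 130-fold higher number from compound 1 to compound 2 (2.10 log units; beyond the scatter) on the other. In the unmeasured compound 4 `O=c1nc(N2CCN(CC3CCCCC3)CC2)sc2c([N+](=O)[O-])cc(C(F)(F)F)cc12` the change from compound 2 is cyclohexylmethyl in place of ((methylsulfanyl)methyl)carbonyl on an amine nitrogen in a ring. The bearing steps are the two large ones out of compound 1, namely a 130-fold higher number from compound 1 to compound 2 (2.10 log units; beyond the scatter) and a 700-fold higher number from compound 1 to compound 3 (2.84 log units; beyond the scatter). Within the data shown here, compound 4 carries cyclohexyl again but lacks the carbonyl, and no measured step covers that loss. A large step to a lower number is therefore expected in this assay. The expected step is a 30-fold lower number from compound 2 to compound 4 (1.48 log units; beyond the scatter). For compound 4 the estimated value is 0.5 ug/mL, with an expected range of 0.08 ug/mL to 4 ug/mL.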

Compound 4, solubility: 9.07 ug/mL
Compound 4: middle estimate off by 18-fold (1.26 log units), on the low side, outside the stated range (above it).
By their numbers in this assay, from the lowest: compound 1; then compounds 4 and 2 (each within the scatter of the next); then compound 3.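

In this assay, the loss of the carbonyl with cyclohexyl kept on the amine nitrogen in a ring gives a 76-fold higher number from compound 1 to compound 4 (1.88 log units; beyond the scatter) and shows that cyclohexyl at this position is compatible with far more than the number of compound 1. Cyclohexylmethyl and ((methylsulfanyl)methyl)carbonyl are not told apart here, at a 1.7-fold lower number from compound 2 to compound 4 (0.22 log units; within the scatter), while the change from acetyl gives a 9.3-fold lower number from compound 3 to compound 4 (0.97 log units; beyond the scatter) and remains beyond the scatter. No data at hand explain these steps.

Going by these compounds, whether the carbonyl step holds for small groups stays open. Ethyl in place of acetyl on this nitrogen would test it, and an amine on the chain is also untested here.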